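The source may hold more compounds than are shown below. What is called first, only, known or untested is meant among the compounds shown, and "the series" means these compounds.

Measured so far in an assay on HEK293 cells for positive allosteric modulation of metabotropic glutamate receptor 2 (Rattus norvegicus), read by thallium flux, with a stated time of 2.5 min; a higher number here means that more compound is needed for the effect, a lower number that less compound is needed:
- compound 1 `COc1cc(C(=O)O)ccc1OCCCCOc1ccc(C(=O)CC(C)(C)C)c(O)c1C`: 47 nM
- compound 2 `CCCC(=O)c1ccc(OCCCCOc2ccc(C(=O)O)cc2C)c(C)c1O`: 104 nM
- compound 3 `Cc1c(OCCCCOc2ccc(C(=O)C(C)C)c(O)c2C)cccc1C(=O)O`: 149 nM

Within this set, compound 2 stands at the second-highest number; its gap to compound 3 lies within the scatter, while compound 1 sits beyond the scatter at a lower number. Compound 4 `CC(=O)c1ccc(OCCCCOc2ccc(C(=O)O)cc2C)c(C)c1O` has not yet been measured. It differs from compound 2 in one place: hydrogen in place of ethyl on a saturated chain carbon bound to a carbonyl carbon. Going by the values given here, no measured pair shows this change, so its direction is not settled by the data. Among the measured compounds the largest group on the carbonyl belongs to compound 1, which gives 47 nM; trimming the chain is therefore expected to cost some potency, with a step of a 2.4-fold higher number from compound 2 to compound 4 (0.38 log units; beyond the scatter) toward a higher number, modestly beyond the scatter. Compound 4 is estimated at 250 nM, with a range from 100 nM to 700 nM.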

Compound 4, half-maximal effective concentration: 50 nM
Compound 4: middle estimate off by 5.0-fold (0.70 log units), on the high side; measured number below the stated range.
By their numbers in this assay, from the lowest: compounds 1 and 4 (each within the scatter of the next); then compounds 2 and 3 (each within the scatter of the next).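

In this assay, the propyl to methyl cut gives a 2.1-fold lower number from compound 2 to compound 4 (0.32 log units; beyond the scatter), so the longer chain in this place is not required for the effect on this core. Compounds 1 and 3 differ from compound 2 in more than one place, so they give no second reading of this change. Nothing available explains the step.

Still open, on these data alone, is how a cyclopropyl or ethyl group would read in place of the methyl of compound 4. As far as these compounds go, whether the same cut holds on the cores of compounds 1 and 3 also remains open.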